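A cyclopentyl group on sulfur at the assay limit

This account rests on a few compounds, and the source may have more. Where it says the series, first, only, none or still open, it means among the compounds named here.

In an ADME assay on MOLT-3 cells (Homo sapiens) for cytotoxicity, with a stated time of 7 days (a higher number here means that more compound is tolerated, a lower number that less compound is tolerated), compound 3 `CC(C)Sc1nc(N)nc2c1ncn2/C=C1/CC1(CO)CO` gives only a limit (> 20000 nM). Compound 1 `COCCOc1nc(N)nc2c1ncn2/C=C1/CC1(CO)CO` also gives a limit (> 20000 nM). Compound 2 `CSc1nc(N)nc2c1ncn2/C=C1/CC1(CO)CO` gives a limit too (> 20000 nM). All three therefore sit at the same end of the scale (the limit of > 20000 nM in this assay, at which 3 of the 3 values shown sit). Compound 4 `Nc1nc(SC2CCCC2)c2ncn(/C=C3/CC3(CO)CO)c2n1` carries cyclopentyl in place of isopropyl on a sulfur. The closest measured change is a step that the two limits leave unreadable from compound 2 to compound 3 and offers no size to carry over, and neither do the other two (a step that the two limits leave unreadable from compound 1 to compound 2 and a step that the two limits leave unreadable from compound 1 to compound 3). No step beyond the scatter is therefore expected in this assay and another limit seems likely. The expected step is small (a number no higher from compound 3 to compound 4 (the limit leaves the size open)). Compound 4 is estimated at 20000 nM (expected range 9000 nM to 40000 nM).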

Compound 4, half-maximal cytotoxic concentration: > 20000 nM
Compound 4: only a limit was reported (the forecaster's own chance of this, stated with the estimate: 70%); the middle value lies on the limit itself.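

Compound 4 gives only a limit in this assay, as do compound 1, compound 2 and compound 3, so no step among them can be read: the limit of > 20000 nM in this assay, at which 4 of the 4 values shown sit.

The concentration at which any of these compounds becomes cytotoxic stays open.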